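Removing a methoxy group in two sulfone and dinitrile indole series

A few compounds are considered here, and "the series" means these few. Any claim that something is new, unique, unknown or untested is made for them only; others in the source may bear on it.

Three compounds were measured in a functional assay on SNB-75 cells (Homo sapiens) for inhibition, read by sulforhodamine B assay, with a stated time of 48 h; on this read-out lower numbers stand for stronger inhibition of growth and higher numbers for weaker inhibition of growth. Compound 1, with the structure `COc1ccc2[nH]c(-c3ccccc3)c(C=C(C#N)C#N)c2c1`, gives 2800 nM. Compound 2, with the structure `COc1ccc(-c2[nH]c3ccc(OC)cc3c2/C=C(\C#N)S(=O)(=O)c2ccccc2)cc1`, gives 612 nM. Compound 3, with the structure `COc1ccc(-c2[nH]c3ccc(OC)cc3c2C=C(C#N)C#N)cc1`, gives 593 nM. Compound 2 and compound 3 carry different cores, and the difference between the two cores is not broken down here; their two values lie within the scatter of each other, so nothing can be said about an order between them.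

Compound 3 and compound 1 differ in one place, described as hydrogen in place of methoxy on an aromatic carbon. This change gave a 4.7-fold higher number from compound 3 to compound 1 (0.67 log units; beyond the scatter) in this assay, a loss of growth inhibition beyond the scatter.

Compound 4, with the structure `COc1ccc2[nH]c(-c3ccccc3)c(/C=C(\C#N)S(=O)(=O)c3ccccc3)c2c1`, has not yet been measured. It differs from compound 2 by hydrogen in place of methoxy on an aromatic carbon. The place of this change is the same, word for word, as the place of the change from compound 3 to compound 1, so the two are the same change, made on the core of compound 2 instead of the core of compound 3.

Going by the values given here, for compound 4 the step from compound 2 is expected to be a 4.6-fold higher number from compound 2 to compound 4 (0.66 log units; beyond the scatter) in this assay, beside the measured 4.7-fold higher number from compound 3 to compound 1 (0.67 log units; beyond the scatter), because a 4.7-fold higher number from compound 3 to compound 1 (0.67 log units; beyond the scatter) is the only precedent for this change, and it rests on that single pair. Compound 4 is therefore estimated at 2800 nM, expected to fall between 1000 nM and 8000 nM.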

Compound 4, concentration for 50% growth inhibition: 5900 nM
Beside the measured number, compound 4's estimate is 2.1-fold (0.32 log units) below it; low and high end bracket the measured number.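

In this assay, exchanging 4-methoxyphenyl for phenyl on the core of compound 2 gave a 9.6-fold higher number from compound 2 to compound 4 (0.98 log units; beyond the scatter), a loss of growth inhibition beyond the scatter. The change therefore raised the number on both cores, and the two steps cannot be told apart in size: the same change on two cores in this assay, a 4.7-fold higher number (0.67 log units; beyond the scatter) from compound 3 to compound 1 and a 9.6-fold higher number (0.98 log units; beyond the scatter) from compound 2 to compound 4, 2.0-fold (0.31 log units) apart, within the scatter of two such steps. Going by these compounds alone, this shows that the loss of growth inhibition seen on one core also appeared on the other, but it rests on only two pairs in a single cell assay, so it does not show that the step has a fixed size, that it would carry over to any further core, or why the methoxy group matters.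

From the compounds shown here alone, only methoxy and hydrogen are seen at this place, so it remains open whether the gain in growth inhibition belongs to methoxy itself or would also come with a hydroxyl group, a chlorine atom or a longer ether such as ethoxy. Going by these compounds, it also remains open whether the same change would cost as much in cell lines other than this one, since every number here comes from the one read-out.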